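This account rests on a few compounds, and the source may have more. Where it says the series, first, only, none or still open, it means among the compounds named here.

Of the compounds shown here, three of one family have been tested in a functional assay on MCF7 cells (Homo sapiens) for cytotoxicity, read by MTT assay, with a stated time of 48 h; on this read-out lower numbers stand for stronger inhibition and higher numbers for weaker inhibition. Compound 1, with the structure `COc1cc(/C=C/C(=O)/C=C/c2nc3ccccc3n2C)ccc1O`, gives 3700 nM in this assay. Compound 2, with the structure `COc1cc(/C=C/C(=O)/C=C/c2nc3c(C)cccc3n2C)ccc1O`, carries one added group on the core of compound 1; this difference, (methyl in place of hydrogen on an aromatic carbon), is the only one between them. In this assay compound 2 gives 3500 nM, so that the step of a 1.1-fold lower number from compound 1 to compound 2 (0.02 log units; within the scatter) is small and does not separate the two compounds.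

Compound 3, with the structure `COc1ccc(/C=C/C(=O)/C=C/c2nc3ccccc3n2C)cc1O`, has the same atoms as compound 1 joined in a different way; the difference between the two cores is not broken down here. In this assay compound 3 gives 3600 nM, and its value and those of compound 1 and compound 2 all lie within the usual scatter of one another, so none can be called stronger or weaker than the others.

Compound 4, with the structure `COc1ccc(/C=C/C(=O)/C=C/c2nc3c(C)cccc3n2C)cc1O`, has not yet been measured in this assay. It carries on the core of compound 3 the difference (methyl in place of hydrogen on an aromatic carbon), the same change that turned compound 1 into compound 2, placed on the same kind of position. Since that earlier step was a 1.1-fold lower number from compound 1 to compound 2 (0.02 log units; within the scatter), the expectation is that the step from compound 3 to compound 4 will also be small, about a 1.1-fold lower number from compound 3 to compound 4 (0.02 log units; within the scatter), a number that stays within the scatter. The estimate for compound 4 in this assay is therefore 3400 nM, expected to fall between 2000 nM and 6000 nM.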

Compound 4, half-maximal inhibitory concentration: 7400 nM
Estimate against measurement, compound 4: 2.2-fold (0.34 log units) below, and the stated range ends below it.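

In this assay, putting methyl in place of hydrogen on an aromatic carbon of the core of compound 3 gives a 2.1-fold higher number from compound 3 to compound 4 (0.31 log units; beyond the scatter) and so modestly weakens inhibition, whereas the same change on the core of compound 1 gives a 1.1-fold lower number from compound 1 to compound 2 (0.02 log units; within the scatter) and so separates those two compounds by no more than ordinary measurement noise. Read alone, one step lies beyond the scatter and the other within it, which might suggest that the core decides what the methyl does, but the comparison that counts is the gap between the two steps, and each step carries the scatter of its own two measurements: the same change on two cores in this assay, a 1.1-fold lower number (0.02 log units; within the scatter) from compound 1 to compound 2 and a 2.1-fold higher number (0.31 log units; beyond the scatter) from compound 3 to compound 4, 2.2-fold (0.34 log units) apart, within the scatter of two such steps. This shows that the two results are compatible with the change acting alike on both cores, but it does not prove that it does, nor does it show that the cores truly differ in their response, and two pairs of compounds cannot settle the matter either way.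

On these data alone, it remains open how other groups on this aromatic carbon, such as an ethyl group, a chlorine atom, an amine or a carboxylic acid, would behave on these two cores. As far as these compounds go, it is also open whether methyl on other carbons of the same ring would give steps of a similar size.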